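The source may report more compounds than this note shows. Statements on the series, on what has been measured and on what is new or still open speak of the compounds shown alone.

In a functional assay on Bel-7402 cells (Homo sapiens) for cytotoxicity, read by MTT assay (a lower number here means a stronger inhibitor, a higher number a weaker inhibitor), three compounds with a shared core have been measured, and they differ only in the group on an amide-type nitrogen. Compound 2 (`CCn1cc(C(=O)Nc2ccc(Cl)cn2)c(=O)c2cc(F)c(N3CCNC(C)C3)c(F)c21`), which carries 5-chloropyridin-2-yl, gives 4900 nM. Compound 1 (`CCn1cc(C(=O)Nc2ccccc2N)c(=O)c2cc(F)c(N3CCNC(C)C3)c(F)c21`), which carries 2-aminophenyl, gives 4800 nM, and the two stand level, with a 1.0-fold higher number from compound 1 to compound 2 (0.01 log units; within the scatter). Compound 3 (`CCn1cc(C(=O)Nc2cccc([N+](=O)[O-])c2)c(=O)c2cc(F)c(N3CCNC(C)C3)c(F)c21`), which carries 3-nitrophenyl, gives 1000 nM. The data show a 4.9-fold lower number from compound 2 to compound 3 (0.69 log units; beyond the scatter), and also a 4.8-fold lower number from compound 1 to compound 3 (0.68 log units; beyond the scatter).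

Compound 4 (`CCn1cc(C(=O)Nc2ccc(OC(F)(F)F)cc2)c(=O)c2cc(F)c(N3CCNC(C)C3)c(F)c21`) has 4-(trifluoromethoxy)phenyl in place of 5-chloropyridin-2-yl on the amide-type nitrogen: 4-(trifluoromethoxy)phenyl in place of 5-chloropyridin-2-yl on an amide-type nitrogen. Among the measured compounds shown here, no measured step makes this exact swap, so the evidence is indirect. Swaps at this same place have ranged from no real change to the modest 4.9-fold lower number from compound 2 to compound 3 (0.69 log units; beyond the scatter), and that step from compound 2 points downward. A modest lean in that direction is therefore expected, not a large jump: a 1.8-fold lower number from compound 2 to compound 4 (0.24 log units; within the scatter). Compound 4 is estimated at 2800 nM, with an expected range of 800 nM to 7000 nM.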

Compound 4, half-maximal inhibitory concentration: 2000 nM
Compound 4: the middle estimate sits 1.4-fold (0.15 log units) above what was measured; the measured number falls inside the stated range.
By their numbers in this assay, from the lowest: compounds 3 and 4 (each within the scatter of the next); then compounds 1 and 2 (each within the scatter of the next).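

The swap to 4-(trifluoromethoxy)phenyl gives a 2.5-fold lower number from compound 2 to compound 4 (0.39 log units; beyond the scatter) and, set against 2-aminophenyl, a 2.4-fold lower number from compound 1 to compound 4 (0.38 log units; beyond the scatter). So 3-nitrophenyl is no longer the only group at this position to clear the level of compounds 1 and 2, and the comparison between the two reads a 2.0-fold higher number from compound 3 to compound 4 (0.30 log units; within the scatter), which leaves them level. The four groups now form two pairs, and a ring of carbon only does not by itself place a compound in the lower pair: compound 1, with 2-aminophenyl, goes against that idea.

Nothing measured here explains why the groups fall into these pairs. Still open, as far as these compounds go, is how an unsubstituted phenyl, a phenyl bearing a carboxylic acid, or a plain alkyl chain on this nitrogen would compare with these four.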